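Hydroxy for chloro on the anilino ring, HT-29 series

This account rests on a few compounds, and the source may have more. Where it says the series, first, only, none or still open, it means among the compounds named here.

Measured compounds:
compound 1 `O=C(/C=C\Nc1ccc(Cl)cc1)c1cn(-c2ccccc2)nc1-c1ccccc1`: 3610 nM
compound 2 `O=C(/C=C\Nc1ccc(F)cc1)c1cn(-c2ccccc2)nc1-c1ccc(F)cc1`: 6500 nM
compound 3 `O=C(/C=C\Nc1ccc(Cl)cc1)c1cn(-c2ccccc2)nc1-c1ccc(F)cc1`: 4600 nM

In a functional assay on HT-29 cells (Homo sapiens) for antiproliferative activity, read by MTT assay, with a stated time of 48 h (a lower number here means a stronger inhibitor, a higher number a weaker inhibitor), compound 1 gives 3610 nM, compound 2 gives 6500 nM and compound 3 gives 4600 nM. Compound 3 holds the second highest of the three numbers; its nearest neighbour is compound 1 and its furthest compound 2, and both gaps lie within the scatter. The two measured steps, a 1.3-fold higher number from compound 1 to compound 3 (0.11 log units; within the scatter) and a 1.4-fold lower number from compound 2 to compound 3 (0.15 log units; within the scatter), are both within the scatter, so neither halogen change on either ring moved this assay.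

Compound 4 `O=C(/C=C\Nc1ccc(O)cc1)c1cn(-c2ccccc2)nc1-c1ccc(F)cc1` differs from compound 3 by hydroxy in place of chloro on an aromatic carbon. For the measured compounds named here, no measured step puts a hydroxy in place of a halogen, so the only bearing precedent is the halogen swap at the same ring, which was within the scatter. The change is therefore expected to give no step beyond the scatter, a 1.1-fold higher number from compound 3 to compound 4 (0.04 log units; within the scatter), with wider uncertainty than the halogen steps showed. Compound 4 is estimated at 5000 nM, within a range of 1800 nM to 14000 nM.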

Compound 4, half-maximal inhibitory concentration: 1900 nM
Estimate against measurement, compound 4: 2.6-fold (0.42 log units) above; the range from low to high includes it.
By their numbers in this assay, from the lowest: compounds 4, 1, 3 and 2 (each within the scatter of the next, the first and the last beyond it).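

Unlike the halogen exchanges, the change from (4-chlorophenyl)amino to (4-hydroxyphenyl)amino moves this assay beyond the scatter, with a 2.4-fold lower number from compound 3 to compound 4 (0.38 log units; beyond the scatter) as its step, so this position does respond to the group it carries. Hydroxy in place of fluoro at the same position points the same way with a 3.4-fold lower number from compound 2 to compound 4 (0.53 log units; beyond the scatter) as its step, and both steps are modest and rest on the single hydroxy compound, compound 4. The data at hand offer no measurement that accounts for the lower number.

Going by these compounds, it remains open whether the step is specific to hydroxy, which a methoxy, an amine or a carboxylic acid at the same carbon would test. On these data alone, it is also open whether the step carries over to the core of compound 1, which has phenyl in place of the 4-fluorophenyl group.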